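Anilide series: acetyl in place of methoxy on compound 1

The source may report more compounds than this note shows. Statements on the series, on what has been measured and on what is new or still open speak of the compounds shown alone.

Among the measured compounds shown here, compound 1 `COc1cccc(NC(=O)c2ccc(OC)c(Nc3nccc(-c4cccnc4)n3)c2)c1` carries the higher of the two numbers measured so far: in a functional assay on K562 cells (Homo sapiens) for antiproliferative activity, read by MTT assay, with a stated time of 48 h (on this read-out lower numbers stand for stronger inhibition and higher numbers for weaker inhibition), compound 1 gives 93100 nM. Compound 2 `COc1ccc(C(=O)Nc2ccc(OCCCN(C)C)cc2)cc1Nc1nccc(-c2cccnc2)n1` gives 38500 nM in this assay, a lower number beyond the scatter. Compound 3 `COc1ccc(C(=O)Nc2cccc(C(C)=O)c2)cc1Nc1nccc(-c2cccnc2)n1` follows from compound 1 by acetyl in place of methoxy on an aromatic carbon. For the measured compounds named here, no step between measured compounds covers this change, so only a small shift, toward a lower number and near the edge of the scatter, is anticipated. Compound 3 is estimated at 65000 nM, between 25000 nM and 180000 nM, an expected step of a 1.4-fold lower number from compound 1 to compound 3 (0.16 log units; within the scatter).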

Compound 3, half-maximal inhibitory concentration: 237000 nM
The estimate for compound 3 lay 3.6-fold (0.56 log units) below the measured number; the whole stated range lies below it.
By their numbers in this assay, from the lowest: compound 2; then compound 1; then compound 3.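

At the aromatic carbon carrying the methoxy of compound 1, acetyl in place of methoxy gives a 2.5-fold higher number from compound 1 to compound 3 (0.41 log units; beyond the scatter) in this assay, so the number at this position responds to this change, and it moves toward weaker inhibition. Among the compounds shown here, the earlier compounds offered no single-place change, so this is the first direct reading of any substituent. Nothing available accounts for the shift.

On these data alone, whether an amine, a carboxylic acid or a longer chain on this same carbon would move the number the other way remains open. As far as these compounds go, whether the hydrogen-bond acceptor shared by methoxy and acetyl matters here also remains open.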